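Working notes on compounds 1 to 4

The source may hold more compounds than are shown below. What is called first, only, known or untested is meant among the compounds shown, and "the series" means these compounds.

Measured so far:
compound 1, `CCCCCCCCCCOP(=O)(O)OCCSC(=S)N1CCCC1`: 67000 nM
compound 2, `CCCCCCCCCCOP(=O)(O)OCCSC(=S)N1CCCCC1`: 24600 nM
compound 3, `CCCCCCOP(=O)(O)OCCSC(=S)N1CCCC1`: 54000 nM

All three were tested in a functional assay on MDA-MB-231 cells (Homo sapiens) for inhibition, read by MTT assay, with stated times of 18 h and 4 h; on this read-out higher numbers stand for weaker inhibition and lower numbers for stronger inhibition. In this assay compound 1 gives 67000 nM, compound 2 gives 24600 nM and compound 3 gives 54000 nM. The change piperidin-1-yl in place of pyrrolidin-1-yl on a thiocarbonyl carbon produced a 2.7-fold lower number from compound 1 to compound 2 (0.44 log units; beyond the scatter). The core of compound 3 differs from that of compound 1 by hydrogen in place of butyl on a saturated chain carbon, six bonds along the chain from an oxygen on an unsaturated carbon, and that change gave a 1.2-fold lower number from compound 1 to compound 3 (0.09 log units; within the scatter).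

Compound 4, `CCCCCCOP(=O)(O)OCCSC(=S)N1CCCCC1`, is not yet measured. It carries on the core of compound 3 the same change that separates compound 2 from compound 1, namely (piperidin-1-yl in place of pyrrolidin-1-yl on a thiocarbonyl carbon); the place is the same in both cases. A step of about a 2.6-fold lower number from compound 3 to compound 4 (0.41 log units; beyond the scatter) is expected, set beside a 2.7-fold lower number from compound 1 to compound 2 (0.44 log units; beyond the scatter), and rests on that single earlier instance alone. Compound 4 is therefore estimated at 21000 nM in this assay, with a likely range from 9000 nM to 50000 nM.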

Compound 4, half-maximal inhibitory concentration: 85000 nM
Estimate against measurement, compound 4: 4.0-fold (0.61 log units) below; measured number above the stated range.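

In this assay, piperidin-1-yl in place of pyrrolidin-1-yl on a thiocarbonyl carbon gives a 1.6-fold higher number from compound 3 to compound 4 (0.20 log units; within the scatter), so the earlier step does not carry over to the core of compound 3: the same change on two cores in this assay, a 2.7-fold lower number (0.44 log units; beyond the scatter) from compound 1 to compound 2 and a 1.6-fold higher number (0.20 log units; within the scatter) from compound 3 to compound 4, 4.3-fold (0.63 log units) apart, beyond the scatter of two such steps

Hydrogen in place of butyl on a saturated chain carbon also depends on the core that carries it, giving a 3.5-fold higher number from compound 2 to compound 4 (0.54 log units; beyond the scatter) on the piperidin-1-yl compounds: the same change on two cores in this assay, a 1.2-fold lower number (0.09 log units; within the scatter) from compound 1 to compound 3 and a 3.5-fold higher number (0.54 log units; beyond the scatter) from compound 2 to compound 4, 4.3-fold (0.63 log units) apart, beyond the scatter of two such steps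

The four compounds show that the two changes do not combine as independent steps, but with a single pair for each step on each core, they do not show which result is typical or why the steps differ.

On these data alone, it stays open whether an octyl chain would behave like the longer or the shorter chain here. As far as these compounds go, it also stays open how a morpholin-4-yl group on the thiocarbonyl carbon would fit these results.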